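The source may hold more compounds than are shown below. What is called first, only, known or untested is meant among the compounds shown, and "the series" means these compounds.

The measured compounds:
compound 1, `CC1=NN(c2ccc(C)cc2)C(=O)C12C=CC(=O)C=C2c1cccc(C)c1`, 19400 nM
compound 2, `CC1=NN(c2ccc(C)cc2)C(=O)C12C=CC(=O)C=C2c1ccccc1`, 46600 nM
compound 3, `CC1=NN(c2ccc(Br)cc2)C(=O)C12C=CC(=O)C=C2c1ccccc1`, reported only as the assay limit > 100000 nM

All three were tested in a functional assay on MDA-MB-231 cells (Homo sapiens) for antiproliferative activity, read by CCK-8 assay, with a stated time of 72 h; a higher number here means a weaker inhibitor, a lower number a stronger inhibitor. Compound 3 stands at the limit of that assay and gives no number, a position described by the limit of > 100000 nM in this assay, at which 1 of the 3 values shown sits. Compound 4 is `CC1=NN(c2ccc(Cl)cc2)C(=O)C12C=CC(=O)C=C2c1ccccc1`; it differs from compound 3 in a single place: chloro in place of bromo on an aromatic carbon. Among the compounds with values here, no measured step swaps one halogen for another. The nearest evidence is the step from compound 2 to compound 3, which brought in the bromo group and gave an at least 2.1-fold higher number from compound 2 to compound 3 (0.33 log units; beyond the scatter), and the step from compound 1 to compound 2, which gave a 2.4-fold higher number from compound 1 to compound 2 (0.38 log units; beyond the scatter). Both changes touched the same aromatic carbon, and both moved the number upward, but neither tells how chloro compares with bromo there. Since that swap is small, compound 4 is expected to sit near compound 3, with a step of a number no higher from compound 3 to compound 4 (the limit leaves the size open) in this assay, which is not beyond the scatter. Compound 4 is therefore estimated at 100000 nM, within a range from 40000 nM to 250000 nM, with a real chance that only a limit is reported.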

Compound 4, half-maximal inhibitory concentration: > 100000 nM
Compound 4 was reported as a limit (the forecaster's own chance of this, stated with the estimate: 60%); the middle value sits exactly at the limit.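

With chloro in place of methyl on this aromatic carbon, para to a large group, the change in this assay gives an at least 2.1-fold higher number from compound 2 to compound 4 (0.33 log units; beyond the scatter), so the upward move is no longer seen with bromo alone but with a second halogen as well. Compound 3 and compound 4 are both reported only as limits, so the step between them cannot be read, and the data cannot rank chloro against bromo at this carbon. What the new result adds is that both halogen compounds now stand at the top of the measurable range, while the methyl of compound 2 still gives a number: the limit of > 100000 nM in this assay, at which 2 of the 4 values shown sit.

The compounds shown leave open how far beyond that limit either halogen compound lies, and whether a different group at this carbon, such as a methoxy group or an amine, would give a number closer to that of compound 2. They also leave open whether the methyl that compound 1 carries and compound 2 lacks would bring a halogen compound back to a readable number.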